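Methoxyphenyl swap on a weakly inhibiting fused core

A few compounds are considered here, and "the series" means these few. Any claim that something is new, unique, unknown or untested is made for them only; others in the source may bear on it.

Measured so far:
compound 1 `Fc1ccc(-c2ccc3nc(-c4ccccc4)cn3c2)cc1`: 22800 nM
compound 2 `Cc1ccc(-c2cn3cc(-c4ccc(F)cc4)ccc3n2)cc1`: 92900 nM

In an assay for inhibition of Retinaldehyde dehydrogenase 3 (Homo sapiens), with a stated time of 5 min (on this read-out lower numbers stand for stronger inhibition and higher numbers for weaker inhibition), compound 2 stands at the higher of the two numbers. Going by the values given here, the only measured step, a 4.1-fold higher number from compound 1 to compound 2 (0.61 log units; beyond the scatter), bears only loosely on the next change. Compound 3 `COc1cccc(-c2cn3cc(-c4ccc(F)cc4)ccc3n2)c1` carries 3-methoxyphenyl in place of 4-methylphenyl on an aromatic carbon. Among the compounds with values here, no measured step covers this exact change, so the expectation rests on compound 2 and on compound 1 with 22800 nM. For compound 3 a modest step downward is expected, a 2.3-fold lower number from compound 2 to compound 3 (0.37 log units; beyond the scatter), giving an estimate of 40000 nM with a range of 12000 nM to 150000 nM.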

Compound 3, half-maximal inhibitory concentration: 21200 nM
Estimate against measurement, compound 3: 1.9-fold (0.28 log units) above; measured number inside the range.
By their numbers in this assay, from the lowest: compounds 3 and 1 (each within the scatter of the next); then compound 2.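

Replacing 4-methylphenyl with 3-methoxyphenyl at this position gives a 4.4-fold lower number from compound 2 to compound 3 (0.64 log units; beyond the scatter), so the higher number of compound 2 does not hold for every substituted phenyl here. Adding methoxy gives a 1.1-fold lower number from compound 1 to compound 3 (0.03 log units; within the scatter), so this substituted ring and the plain phenyl ring of compound 1 cannot be told apart in this assay. No supporting evidence is available to explain either step.

The step from compound 2 swaps the group and its place on the phenyl ring together, so the two contributions remain unseparated. On these data alone, how an amine or a carboxylic acid on this ring would read out remains open.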